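Switching the amide substituent on a propargylamine ether series

The compounds below may be only part of what the source reports. "The series", "measured", "known", "first", "only" and "open" are said of these compounds alone.

Compounds measured in an ADME assay on cells for inhibition of Amine oxidase [flavin-containing] A (Homo sapiens), read by fluorescence and Amplex Red, with stated times of 30 min and 15 min; a lower number here means a stronger inhibitor, a higher number a weaker inhibitor:
- compound 1, `C#CCNC1CCc2c(OCCc3cc(NC(C)=O)ccc3Cl)cccc21`, gives 85200 nM
- compound 2, `C#CCNC1CCc2c(OCCc3cc(NC(=O)c4cccc(F)c4)ccc3Cl)cccc21`, gives "not determined" (no result reported)
- compound 3, `C#CCNC1CCc2c(OCCc3cc(NC(=O)c4ccc(Cl)cc4)ccc3Cl)cccc21`, gives "not determined" (no result reported)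

Compound 3 carries a (4-chlorophenyl)carbonyl group on the amide nitrogen, and in this assay compound 3 has no single number; compound 2 is the one further entry without a number. Only compound 1, with its acetamide, gives a figure, and that figure marks it as a weak inhibitor.

Compound 4, `C#CCNC1CCc2c(OCCc3cc(NC(=O)COC(C)=O)ccc3Cl)cccc21`, differs from compound 3 in one place: acetoxymethyl in place of 4-chlorophenyl on a carbonyl carbon. For the measured compounds named here, no step between measured compounds is available to size this change. The acetoxymethyl carbonyl of compound 4 is closer in kind to the small acetamide of compound 1 than to the aryl amide of compound 3, so compound 4 is expected to land near where compound 1 stands in this assay, with a real chance that only a limit is reported. Compound 4 is estimated at 80000 nM, in a range from 20000 nM to 300000 nM.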

Compound 4, half-maximal inhibitory concentration: 437000 nM
For compound 4 the middle estimate is 5.5-fold (0.74 log units) below the measured one; the whole stated range lies below it.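

In this assay, for the compounds shown here, acetoxy in place of hydrogen on a saturated chain carbon bound to a carbonyl carbon gives a 5.1-fold higher number from compound 1 to compound 4 (0.71 log units; beyond the scatter) and so makes compound 4 the weaker inhibitor, which is the first sign that the number responds to a change at this position. The change from 4-chlorophenyl to acetoxymethyl on the carbonyl carbon cannot be read, since compound 3 has no single number. Nothing measured here accounts for the step.

As far as these compounds go, whether aryl amides such as compound 2 and compound 3 stand above or below compound 1 remains open. From the compounds shown here alone, it also remains open whether the step belongs to the acetoxy group specifically or would recur with a hydroxymethyl group, an aminomethyl group or a longer alkyl chain on the same carbonyl carbon.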